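Aryl variation on the shared diarylurea core

The compounds below may be only part of what the source reports. "The series", "measured", "known", "first", "only" and "open" are said of these compounds alone.

Measured so far:
compound 1, `COc1ccc(Br)cc1Nc1cc(NC(=O)Nc2c(Cl)cccc2Cl)ncn1`: 53.3%
compound 2, `COc1ccc(OC)c(Nc2cc(NC(=O)Nc3c(Cl)cccc3Cl)ncn2)c1`: 93.1%
compound 3, `COc1ccc(C(F)(F)F)cc1Nc1cc(NC(=O)Nc2c(Cl)cccc2Cl)ncn1`: 69.1%

In a functional assay on NCI-H1581 cells (Homo sapiens) for inhibition, read by MTT assay, with a stated time of 48 h, tested at 10 uM (a higher number here means more inhibition at the concentration tested (going by the name of the read-out), a lower number less inhibition), compound 1 gives the lowest of the three numbers. The nearest is compound 3, with a number 15.8 percentage points higher from compound 1 to compound 3 (beyond the scatter); the furthest is compound 2, with a number 39.8 percentage points higher from compound 1 to compound 2 (beyond the scatter). Between compounds 2 and 3 the step is a number 24 percentage points lower from compound 2 to compound 3 (beyond the scatter).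

Compound 4, `Cc1ccc(Nc2cc(NC(=O)Nc3c(Cl)cccc3Cl)ncn2)cc1C`, is not yet measured. Relative to compound 1 its change is 3,4-dimethylphenyl in place of 5-bromo-2-methoxyphenyl on a nitrogen on an aromatic ring. Both measured steps from compound 1 bear on it only in part: each replaces the bromo alone while keeping the methoxy, whereas here the whole 5-bromo-2-methoxyphenyl is exchanged for 3,4-dimethylphenyl. Among the measured compounds shown here, both replacements of bromo gave higher numbers, one large, one modest, so a rise beyond the scatter is expected, but its size is uncertain since no measured step removes the methoxy or introduces methyl groups.

Compound 4 is expected to give 66% in this assay, within 42% to 88%, which means an estimated step of a number 12.7 percentage points higher from compound 1 to compound 4 (beyond the scatter).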

Compound 4, a percentage reported as inhibition, at one concentration (the size of the read-out at that concentration, not a potency): 73.3%
Beside the measured number, compound 4's estimate is 7.3 percentage points below it, and the stated range covers the measured number.
By their numbers in this assay, from the lowest: compound 1; then compounds 3 and 4 (each within the scatter of the next); then compound 2.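

In this assay, among the compounds shown here, the exchange gives a number 20 percentage points higher from compound 1 to compound 4 (beyond the scatter) and so shows what the bromo replacements in the earlier compounds could not: on this nitrogen, the methoxy and the bromo can both be absent without the number falling below that of compound 1. The entering 3,4-dimethylphenyl is carbon only and has 0 hydrogen-bond acceptors, so a hydrogen-bond acceptor on this aryl group is not required to reach this level of inhibition. Nothing available explains this step.

The step combines the loss of the bromo, the loss of the methoxy and the arrival of two methyl groups, and the compounds shown do not separate these contributions. Also open, from the compounds shown here alone, is how this position responds to a dimethylamino group or a carboxylic acid on the aryl ring.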